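Trifluorophenyl cinnamamide expected near its methoxyphenyl parent

A few compounds are considered here, and "the series" means these few. Any claim that something is new, unique, unknown or untested is made for them only; others in the source may bear on it.

Compound 3 `COc1ccc(/C=C/C(=O)Nc2cc(C(=O)c3cc(OC)c(OC)c(OC)c3)cc(OC)c2OC)cc1` sits second highest of the three numbers recorded in a functional assay on B16 cells (Mus musculus) for cytotoxicity, read by MTT assay, with a stated time of 72 h; on this read-out higher numbers stand for weaker inhibition and lower numbers for stronger inhibition; compound 3 gives 9400 nM. Within the data shown here, its nearest neighbour is compound 1 `COc1ccc(/C=C/C(=O)Nc2cc(C(=O)c3cc(OC)c(OC)c(OC)c3)ccc2OC)cc1`, which in this assay gives 8700 nM, and the gap between them, a 1.1-fold higher number from compound 1 to compound 3 (0.03 log units; within the scatter), is the sole step that compares a methoxy with a hydrogen on an aromatic carbon. The furthest of the three is compound 2 `COc1cc(/C=C/C(=O)Nc2cc(C(=O)c3cc(OC)c(OC)c(OC)c3)ccc2OC)ccc1F`, which in this assay gives 16300 nM.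

Compound 4 `COc1cc(C(=O)c2cc(OC)c(OC)c(OC)c2)cc(NC(=O)/C=C/c2cc(F)c(F)c(F)c2)c1OC` arises from compound 3 by the change (3,4,5-trifluorophenyl in place of 4-methoxyphenyl on a double-bonded chain carbon bound to a double-bonded chain carbon). Among the measured compounds shown here, the one measured step that touches the same place is a 1.9-fold higher number from compound 1 to compound 2 (0.27 log units; within the scatter), where the 4-methoxyphenyl on the double-bonded chain carbon gave way to a 4-fluoro-3-methoxyphenyl. That step stayed within the scatter, though it pointed toward a higher number. Compound 4 carries a 3,4,5-trifluorophenyl, a further departure from the 4-methoxyphenyl than compound 2 made, so a shift of similar or somewhat larger size toward a higher number in this assay is expected, with a real chance that it stays within the scatter.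

The estimate for compound 4 is therefore 15000 nM, between 6000 nM and 40000 nM, which means an expected step of a 1.6-fold higher number from compound 3 to compound 4 (0.20 log units; within the scatter).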

Compound 4, half-maximal inhibitory concentration: 5200 nM
Compound 4: the middle estimate sits 2.9-fold (0.46 log units) above what was measured, and the stated range ends above it.
By their numbers in this assay, from the lowest: compounds 4, 1, 3 and 2 (each within the scatter of the next, the first and the last beyond it).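

In this assay, the exchange of the 4-methoxyphenyl for a 3,4,5-trifluorophenyl on a double-bonded chain carbon bound to a double-bonded chain carbon gives a 1.8-fold lower number from compound 3 to compound 4 (0.26 log units; within the scatter), so a ring with three fluorines and no methoxy group is tolerated at this place on the core of compound 3. The earlier step at the same place, a 1.9-fold higher number from compound 1 to compound 2 (0.27 log units; within the scatter), pointed the other way on a different core, and since both steps lie within the scatter, neither establishes a direction for fluorine substitution on this ring. No measured evidence bears on this result, so nothing can be said about what lies behind it.

The compounds shown leave open whether any replacement at this place can move the number beyond the scatter, for example a ring carrying an amine or a carboxylic acid, or a longer chain in place of the ethenyl link. They also leave open whether the 3,4,5-trifluorophenyl would give a similar number on the core of compound 1, which lacks the added methoxy of compound 3.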